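The source may hold more compounds than are shown below. What is called first, only, known or untested is meant among the compounds shown, and "the series" means these compounds.

Compound 1 `C=C1C(=O)[C@]23C[C@@]1(O)CC[C@H]2c1ccc(O)c(C)c1[C@@H]3Cn1cc(-c2ccc(C(F)(F)F)cc2)nn1` carries a trifluoromethyl on the aromatic carbon, and in a functional assay on SW480 cells (Homo sapiens) for cytotoxicity, read by MTT assay, with a stated time of 4 days (on this read-out lower numbers stand for stronger inhibition and higher numbers for weaker inhibition), compound 1 gives 370 nM. Compound 2 `C=C1C(=O)[C@]23C[C@@]1(O)CC[C@H]2c1ccc(O)c(C)c1[C@@H]3Cn1cc(-c2ccc(C)cc2)nn1`, with methyl in place of that trifluoromethyl, gives in this assay a value of 330 nM, and compound 3 `C=C1C(=O)[C@]23C[C@@]1(O)CC[C@H]2c1ccc(O)c(C)c1[C@@H]3Cn1cc(-c2ccc(Br)cc2)nn1`, with bromo in that place, gives in this assay a value of 310 nM. The step of a 1.1-fold lower number from compound 1 to compound 2 (0.05 log units; within the scatter) and the step of a 1.2-fold lower number from compound 1 to compound 3 (0.08 log units; within the scatter) both stay within the scatter, as does the step of a 1.1-fold lower number from compound 2 to compound 3 (0.03 log units; within the scatter). Compound 3 has the lowest number of the three, yet its gaps to compound 2 and to compound 1 fall within the scatter, so no order among them can be claimed.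

Compound 4 `C=C1C(=O)[C@]23C[C@@]1(O)CC[C@H]2c1ccc(O)c(C)c1[C@@H]3Cn1cc(-c2ccc(Cl)cc2)nn1` differs from compound 3 in one place: chloro in place of bromo on an aromatic carbon. Within the data shown here, no measured step brings in chloro, so the three steps among compound 1, compound 2 and compound 3 are the closest guide, and each of them, whether the group entering was methyl, bromo or trifluoromethyl, stayed within the scatter. Compound 4 is therefore expected to show no step beyond the scatter in this assay, the expected step being a 1.0-fold higher number from compound 3 to compound 4 (0.01 log units; within the scatter). For compound 4 the estimate in this assay is 320 nM, with a range from 160 nM to 640 nM.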

Compound 4, half-maximal inhibitory concentration: 280 nM
The estimate for compound 4 lay 1.1-fold (0.06 log units) above the measured number; the measured number falls inside the stated range.
By their numbers in this assay, from the lowest: compounds 4, 3, 2 and 1 (each within the scatter of the next).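

With chloro, a fourth group is now on the aromatic carbon para to a large group, and in this assay it separates from none of the other three: a 1.1-fold lower number from compound 3 to compound 4 (0.04 log units; within the scatter) and a 1.2-fold lower number from compound 2 to compound 4 (0.07 log units; within the scatter) and a 1.3-fold lower number from compound 1 to compound 4 (0.12 log units; within the scatter). The bromo to chloro change exchanges one heavy atom for one heavy atom with no change in ring, charge or hydrogen-bond count, and it adds a second halogen comparison to the earlier ones, so the four compounds now form a set in which bromo, chloro, methyl and trifluoromethyl cannot be told apart at this position on this read-out. No measurement is at hand that would explain this flat result.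

From the compounds shown here alone, all four groups are uncharged and carry no hydrogen-bond donors or acceptors by the count given for bromo and chloro, so it stays open whether an amine, a carboxylic acid, a hydroxyl or a longer alkyl chain at this position would give a step beyond the scatter. Also open, going by these compounds, is whether the same flatness would hold with these groups elsewhere on the aromatic ring or in cells other than those of this assay.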